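Notes on a new group at the amide nitrogen

The source may hold more compounds than are shown below. What is called first, only, known or untested is meant among the compounds shown, and "the series" means these compounds.

In an ADME assay on MT4 cells (Homo sapiens) for cytotoxicity, read by MTT assay, with a stated time of 5 days (on this read-out lower numbers stand for higher toxicity in this test and higher numbers for lower toxicity in this test), compound 1 `Cc1cc(C)cc(S(=O)(=O)c2c(C(=O)N[C@H]3CCN(CC(N)=O)C3)[nH]c3ccc(Cl)cc23)c1` gives 28100 nM. Compound 2 `Cc1cc(C)cc(S(=O)(=O)c2c(C(=O)NC3CN(CC(N)=O)C3)[nH]c3ccc(Cl)cc23)c1` gives 25500 nM, and the two numbers lie within the scatter of each other, so neither ranks over the other.

Compound 3 `Cc1cc(C)cc(S(=O)(=O)c2c(C(=O)NS(=O)(=O)c3ccc(F)cc3F)[nH]c3ccc(Cl)cc23)c1` departs from compound 2 as follows: (2,4-difluorophenyl)sulfonyl in place of 1-(carbamoylmethyl)azetidin-3-yl on an amide-type nitrogen. In words, (2,4-difluorophenyl)sulfonyl stands in place of 1-(carbamoylmethyl)azetidin-3-yl on an amide-type nitrogen, so a six-membered aromatic ring of carbon only replaces a four-membered non-aromatic ring with 1 hetero atom.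

Among the measured compounds shown here, only one measured step bears on this: a 1.1-fold lower number from compound 1 to compound 2 (0.04 log units; within the scatter). That step stays within the scatter, but it only exchanges one ring for another under the same carbamoylmethyl side chain. For the measured compounds named here, no measured compound carries a sulfonyl group on this nitrogen, so the series gives little guidance on size or direction. A modest move towards a lower number in this assay is expected, held loosely, and the range is kept wide. The expected change is a 2.1-fold lower number from compound 2 to compound 3 (0.33 log units; beyond the scatter). For compound 3 the estimated value is 12000 nM, with an expected range of 4000 nM to 35000 nM.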

Compound 3, half-maximal cytotoxic concentration: 121000 nM
For compound 3 the middle estimate is 10-fold (1.00 log units) below the measured one; the measured number lies above the stated range.
By their numbers in this assay, from the lowest: compounds 2 and 1 (each within the scatter of the next); then compound 3.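

In this assay the substituent on the amide-type nitrogen proves able to shift the number: the exchange between the two carbamoylmethyl-bearing rings gave no readable change, whereas (2,4-difluorophenyl)sulfonyl gives a 4.7-fold higher number from compound 2 to compound 3 (0.68 log units; beyond the scatter) and likewise a 4.3-fold higher number from compound 1 to compound 3 (0.63 log units; beyond the scatter) in the direction of lower toxicity in this test. The two steps point the same way, so among these compounds the rise does not depend on which of the two rings leaves, and this nitrogen carries a sulfonyl group with a six-membered aromatic ring of carbon only, and with no hydrogen-bond donor in the entering group, without any fall in the number. Nothing measured here speaks to the reason for the rise.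

On these data alone, the sulfonyl group, the aromatic ring and the fluorine atoms all enter in a single step, and the loss of the carbamoylmethyl chain comes with them, so their separate shares remain open. A phenylsulfonyl group without fluorine, a methylsulfonyl group or a 2,4-difluorobenzoyl group on this nitrogen would begin to divide those shares.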